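Coumarin-triazole dienone series: growth inhibition notes

The source may report more compounds than this note shows. Statements on the series, on what has been measured and on what is new or still open speak of the compounds shown alone.

Measured compounds:
compound 1, `COc1ccccc1/C=C/C(=O)/C=C/c1ccc(OCc2cn(CCCCOc3cc(=O)oc4ccccc34)nn2)c(OC)c1`: 47%
compound 2, `COc1cc(/C=C/C(=O)/C=C/c2ccccc2)ccc1OCc1cn(CCCCCOc2cc(=O)oc3ccccc23)nn1`: 22%
compound 3, `COc1ccc(/C=C/C(=O)/C=C/c2ccc(OCc3cn(CCCOc4cc(=O)oc5ccccc45)nn3)c(OC)c2)cc1OC`: 65%

In a functional assay on COLO 205 cells (Homo sapiens) for inhibition, read by sulforhodamine B assay, with a stated time of 48 h, tested at 50 uM (a higher number here means more inhibition of growth at the concentration tested, a lower number less inhibition of growth), compound 1 gives 47%, the second highest of the three numbers. The nearest neighbour is compound 3, which in this assay gives 65%, a number beyond the scatter above compound 1; the furthest is compound 2, which in this assay gives 22%, beyond the scatter below compound 1. Compound 3 carries the 3,4-dimethoxyphenyl end and compound 2 the plain phenyl end, so across these three numbers the dimethoxy end goes with the higher reading.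

Compound 4, `COc1ccc(/C=C/C(=O)/C=C/c2ccc(OCc3cn(CCCCOc4cc(=O)oc5ccccc45)nn3)c(OC)c2)cc1OC`, has not been measured. It differs from compound 1 as 3,4-dimethoxyphenyl in place of 2-methoxyphenyl on a double-bonded chain carbon bound to a double-bonded chain carbon. Within the data shown here, no step between two measured compounds matches this change exactly, so the direction is taken from what the three numbers show. An upward step of moderate size is expected for a number 13 percentage points higher from compound 1 to compound 4 (beyond the scatter), because compound 3, which shares the 3,4-dimethoxyphenyl end, gives 65%. Compound 4 is estimated at 60%, expected to fall between 42% and 78%.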

Compound 4, percent growth inhibition at one concentration: 53%
Compound 4: middle estimate off by 7 percentage points, on the high side; measured number inside the range.
By their numbers in this assay, from the lowest: compound 2; then compounds 1 and 4 (each within the scatter of the next); then compound 3.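

In this assay the change to 3,4-dimethoxyphenyl in place of 2-methoxyphenyl, on a double-bonded chain carbon bound to a double-bonded chain carbon, gives a number 6 percentage points higher from compound 1 to compound 4 (within the scatter) with all else in the structure held the same. Among these compounds, this is the first reading of the change in one place only, and the higher reading that went with the 3,4-dimethoxyphenyl end across the earlier numbers does not appear in it, so at this position the two ends are not separated. No measurement at hand bears on why the step is this small.

Going by these compounds, whether the same change reads alike on a chain of another length remains open. Also open, on these data alone, is what a dimethylamino or carboxylic acid group on this phenyl end would do to growth inhibition.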